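Chloro in place of acetyl: expected binding of compound 4

A few compounds are considered here, and "the series" means these few. Any claim that something is new, unique, unknown or untested is made for them only; others in the source may bear on it.

Three compounds of the series share the core of compound 1 `CN(CC1=CC[C@H]2C[C@@H]1C2(C)C)Cc1ccc(Br)cc1` and differ only at the aromatic carbon that carries bromo in compound 1. In an assay on HEK293 cells for displacement of a labelled ligand from C-X-C chemokine receptor type 3 (Homo sapiens) (on this read-out higher numbers stand for weaker inhibition and lower numbers for stronger inhibition), compound 1 gives 3160 nM. Compound 2 `CN(CC1=CC[C@H]2C[C@@H]1C2(C)C)Cc1ccc(-c2ccccc2)cc1`, with phenyl in place of bromo, gives 3160 nM in this assay, so no change at the digits printed from compound 1 to compound 2 (within the scatter). Compound 3 `CC(=O)c1cccc(-c2ccc(CN(C)CC3=CC[C@H]4C[C@@H]3C4(C)C)cc2)c1` carries 3-acetylphenyl at that carbon. For compound 3 only a limit is recorded in this assay, namely > 316 nM. Thus a step that the limit leaves unreadable from compound 1 to compound 3 and a step that the limit leaves unreadable from compound 2 to compound 3; both steps are hidden by the limit of > 316 nM in this assay, at which 1 of the 3 values shown sits.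

Compound 4 `CN(CC1=CC[C@H]2C[C@@H]1C2(C)C)Cc1ccc(-c2cccc(Cl)c2)cc1` is the next member: chloro in place of acetyl on an aromatic carbon. Only the two unreadable steps touch this position directly, while the step from bromo to phenyl, no change at the digits printed from compound 1 to compound 2 (within the scatter), shows that replacing bromo by an aromatic ring left the value where it was. The starting value being a limit, the expected step that the limit leaves unreadable from compound 3 to compound 4 rests on no readable measured step and is a guess. Near the values of the first two members is where compound 4 is expected, estimated at 2500 nM with a range from 600 nM to 10000 nM.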

Compound 4, inhibition constant: 3980 nM
The estimate for compound 4 lay 1.6-fold (0.20 log units) below the measured number, within the range that was stated.
By their numbers in this assay, from the lowest: compounds 1, 2 and 4 (each within the scatter of the next).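

In this assay, 3-chlorophenyl in place of bromo gives a 1.3-fold higher number from compound 1 to compound 4 (0.10 log units; within the scatter), and the addition of chloro to the phenyl ring gives a 1.3-fold higher number from compound 2 to compound 4 (0.10 log units; within the scatter). For the compounds shown here, a substituted phenyl ring at this carbon therefore has a readable value for the first time, and compound 1, compound 2 and compound 4 cannot be told apart on this read-out. The step from compound 3 to compound 4 and the other steps to compound 3 cannot be read, since compound 3 has only a limit: the limit of > 316 nM in this assay, at which 1 of the 4 values shown sits.

On these data alone, whether acetyl and chloro at this place differ at all remains open. Also open, as far as these compounds go, is whether an amine, a carboxylic acid or a longer chain in place of chloro would move the value beyond the scatter.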